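The compounds below may be only part of what the source reports. "The series", "measured", "known", "first", "only" and "open" are said of these compounds alone.

In an ADME assay on NIH3T3 cells (Mus musculus) for cytotoxicity, read by MTT assay, with a stated time of 24 h (a higher number here means a weaker inhibitor, a lower number a stronger inhibitor), compound 1 `Sc1nnc(-c2cnccn2)n1/N=C/c1ccc(Cl)cc1Cl` gives 206000 nM and compound 2 `Sc1nnc(-c2cnccn2)n1/N=C/c1ccc(Cl)cc1` gives 218000 nM, so the two stand level within the scatter. Compound 3 `Oc1ccc(/C=N/n2c(S)nnc2-c2cnccn2)cc1` differs from compound 2 by hydroxy in place of chloro on an aromatic carbon, para to a large group: hydroxy in place of chloro on an aromatic carbon. Among the compounds with values here, the only measured step that bears on this is a 1.1-fold higher number from compound 1 to compound 2 (0.02 log units; within the scatter), which replaces a chloro with hydrogen rather than hydroxy and so offers only loose guidance. In this assay the expected change is a 1.3-fold lower number from compound 2 to compound 3 (0.11 log units; within the scatter), with none expected beyond the scatter. For compound 3 the estimated value is 170000 nM, with an expected range of 60000 nM to 350000 nM.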

Compound 3, half-maximal inhibitory concentration: 175000 nM
Compound 3: middle estimate off by 1.0-fold (0.01 log units), on the low side; low and high end bracket the measured number.
By their numbers in this assay, from the lowest: compounds 3, 1 and 2 (each within the scatter of the next).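

The change from 4-chlorophenyl to 4-hydroxyphenyl gives, in this assay, a 1.2-fold lower number from compound 2 to compound 3 (0.10 log units; within the scatter). This is the first step shown on this aromatic carbon, para to a large group, since the earlier step removed a different chloro. Here, exchanging chloro for hydroxy, which adds a hydrogen-bond donor and a hydrogen-bond acceptor, leaves the number within the scatter, and no measurement shown offers an explanation for this result. From the compounds shown here alone, whether an amine, a carboxylic acid or a methoxy group here would also stay within the scatter remains open. So does whether hydroxy would behave alike with the second chloro of compound 1 present.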